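The source may hold more compounds than are shown below. What is called first, only, known or untested is meant among the compounds shown, and "the series" means these compounds.

Measured compounds in an assay on FRT cells with Cystic fibrosis transmembrane conductance regulator variant F508del (Homo sapiens) as the target, read by fluorescence, with a stated time of 25 min; on this read-out higher numbers stand for larger maximal responses and lower numbers for smaller maximal responses:

compound 1 `NC(=O)C1CCN(c2nc(-c3ccccn3)nc3c2CN(Cc2ccccc2)CC3)CC1`: 56.6%
compound 2 `NC(=O)CN1CCN(c2nc(-c3ccccn3)nc3c2CN(Cc2ccccc2)CC3)CC1`: 57.9%
compound 3 `NC(=O)C1CCN(c2nc(-c3cccnc3)nc3c2CN(Cc2ccccc2)CC3)CC1`: "not active" (no number reported), no number given

Compounds 1 and 2 share a core that carries a pyridin-2-yl group; in this assay compound 1 gives 56.6% and compound 2 gives 57.9%. Among the measured compounds shown here, the one change between them, 4-(carbamoylmethyl)piperazin-1-yl in place of 4-carbamoylpiperidin-1-yl on an aromatic carbon, gives a number 1.3 percentage points higher from compound 1 to compound 2 (within the scatter), so this change leaves the maximal response as it was.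

Compound 3 carries a pyridin-3-yl group in place of the pyridin-2-yl group of compound 1 and stands apart from both: in this assay compound 3 is recorded as "not active" (no number reported), and no single number is available for it.

Compound 4 `NC(=O)CN1CCN(c2nc(-c3cccnc3)nc3c2CN(Cc2ccccc2)CC3)CC1` is the not yet measured partner of compound 3. The difference is 4-(carbamoylmethyl)piperazin-1-yl in place of 4-carbamoylpiperidin-1-yl on an aromatic carbon. For the measured compounds named here, the only measured step that bears on it is the one from compound 1 to compound 2, which lies within the scatter. Going by the values given here, no step beyond the scatter is therefore expected in this assay from compound 3 to compound 4, and a low or absent maximal response is the likely outcome, with the most probable result being a report for compound 4 that matches the one for compound 3, "not active" (no number reported).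

Compound 4 is estimated at 10%, within a range of 0% to 35%.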

Compound 4, largest response reached (Emax), in percent of the reference or control that the assay uses: "not active" (no number reported)
The entry for compound 4 holds no number; the estimate stays without a comparison.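

In this assay compound 3 and compound 4 both stand without a number, so no step can be read between them. The compounds shown leave open whether 4-(carbamoylmethyl)piperazin-1-yl in place of 4-carbamoylpiperidin-1-yl changes anything on the core carrying the pyridin-3-yl group. No supporting evidence bears on this result.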